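The source may report more compounds than this note shows. Statements on the series, on what has been measured and on what is new or still open speak of the compounds shown alone.

Working notes on the series. Compound 1 `Oc1ccc(CNc2ncnc3c2ncn3C2CCCCO2)cc1`, compound 2 `COc1ccc(CNc2ncnc3c2ncn3C2CCCCO2)cc1` and compound 3 `COc1cccc(CNc2ncnc3c2ncn3C2CCCCO2)c1O` are measured; compound 4 `Oc1cccc(CNc2ncnc3c2ncn3C2CCCCO2)c1O` is not. In an ADME assay on BJ cells (Homo sapiens) for cytotoxicity, read by MTT assay, with a stated time of 72 h (on this read-out higher numbers stand for weaker inhibition and lower numbers for stronger inhibition), compound 1 gives only a limit, > 100000 nM. In this assay compound 2 also gives only a limit, > 100000 nM. In this assay compound 3 again gives only a limit, > 100000 nM. The change from compound 2 to compound 1 is hydrogen in place of methyl on an oxygen on an aromatic ring, and its step, a step that the two limits leave unreadable from compound 2 to compound 1, is unreadable because of the limit of > 100000 nM in this assay, at which 3 of the 3 values shown sit. The change from compound 3 to compound 4 is hydrogen in place of methyl on an oxygen on an aromatic ring, the same change at the same place. The difference between the cores of compound 2 and compound 3 is not broken down here. The expected step is a step that the limit leaves unreadable from compound 3 to compound 4, since the same change read a step that the two limits leave unreadable from compound 2 to compound 1. Compound 4 is estimated in this assay at 150000 nM, between 50000 nM and 500000 nM.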

Compound 4, half-maximal inhibitory concentration: 63300 nM
Beside the measured number, compound 4's estimate is 2.4-fold (0.37 log units) above it; the measured number falls inside the stated range.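

In this assay, hydrogen in place of methyl on an oxygen on an aromatic ring gives an at least 1.5-fold lower number from compound 3 to compound 4 (0.19 log units; that floor lies within the scatter), and the two replacements by 2,3-dihydroxyphenyl give an at least 1.5-fold lower number from compound 2 to compound 4 (0.19 log units; that floor lies within the scatter) and an at least 1.5-fold lower number from compound 1 to compound 4 (0.19 log units; that floor lies within the scatter). These floors establish no real shift, and the same change on the other core cannot be read, so neither its size nor its direction is shown to carry from one core to the other. The floors rest on limits rather than on paired numbers: the limit of > 100000 nM in this assay, at which 3 of the 4 values shown sit.

Still open, going by these compounds, is how the number in this assay responds to an amine or a carboxylic acid on the phenyl ring. Also open, on these data alone, is the effect of a longer chain in place of the methyl on that oxygen.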